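Replacing pyrrolidin-1-yl with sec-butyl in compound 3

A few compounds are considered here, and "the series" means these few. Any claim that something is new, unique, unknown or untested is made for them only; others in the source may bear on it.

In a physicochemical assay for metabolic stability, read by LC-MS, in simulated gastric fluid, with a stated time of 15 min, tested at 50 uM (on this read-out higher numbers stand for a more stable compound and lower numbers for a less stable compound), compound 3 `O=C(Oc1ccccc1N1CCCC1)c1coc(-c2ccccc2)n1` has 0.1% remaining, compound 1 `CCC(=O)c1ccccc1OC(=O)c1coc(-c2ccccc2)n1` has 1.8% remaining and compound 2 `Cc1cc(C)c(OC(=O)c2coc(-c3ccccc3)n2)c(C)c1` has 1.4% remaining. These three numbers lie within the scatter of one another, so compound 3 cannot be ranked against the other two, and all three sit close to the bottom of the scale.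

Compound 4 `CCC(C)c1ccccc1OC(=O)c1coc(-c2ccccc2)n1` carries sec-butyl in place of pyrrolidin-1-yl on an aromatic carbon and keeps the shared core. One measured step also exchanges a group on an aromatic carbon: pyrrolidin-1-yl in place of propanoyl gave a number 1.7 percentage points lower from compound 1 to compound 3 (within the scatter) and so offers no sign of a large effect. No step beyond the scatter is therefore expected in this assay for this new exchange. The step expected is a number 1.4 percentage points higher from compound 3 to compound 4 (within the scatter) and would not count as a real change. The estimated value for compound 4 is 1.5% with an expected range from 0.1% to 6% on this read-out.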

Compound 4, percent of the compound remaining: 0.2%
Beside the measured number, compound 4's estimate is 1.3 percentage points above it, within the range that was stated.
By their numbers in this assay, from the lowest: compounds 3, 4, 2 and 1 (each within the scatter of the next).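

In this assay, an open branched chain and a saturated nitrogen ring cannot be told apart at this place, ortho to a large group: sec-butyl in place of pyrrolidin-1-yl gives a number 0.1 percentage points higher from compound 3 to compound 4 (within the scatter) and so no real change. Sec-butyl in place of propanoyl gives a number 1.6 percentage points lower from compound 1 to compound 4 (within the scatter) and is no real change either, so sec-butyl, pyrrolidin-1-yl and propanoyl all leave the shared core close to the bottom of the scale. Nothing available explains why these numbers are so low.

As far as these compounds go, it remains open whether any group on this aromatic carbon, such as a carboxylic acid or a longer chain, could bring a real change in this read-out. Small differences among compounds this close to the bottom of the scale also remain out of reach.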